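Arylmethyl substituent variation on the shared amidine-oxadiazole series

The source may report more compounds than this note shows. Statements on the series, on what has been measured and on what is new or still open speak of the compounds shown alone.

In an assay for inhibition of Amine oxidase [flavin-containing] A (Homo sapiens), read by fluorescence and spectrophotometry, using microsomes, with stated times of 30 min and 20 min (a higher number here means a weaker inhibitor, a lower number a stronger inhibitor), compound 3 `c1ncn(Cc2ccc(-c3noc(-c4ccc(C5=NCCN5)cc4)n3)cc2)n1` gives 24600 nM, the highest number of the three measured. Compound 1 `CC(C)(C)c1ccc(-c2noc(-c3ccc(C4=NCCN4)cc3)n2)cc1` gives 751 nM and compound 2 `c1ccc(Oc2ccc(-c3noc(-c4ccc(C5=NCCN5)cc4)n3)cc2)cc1` gives 2770 nM; the steps were a 33-fold higher number from compound 1 to compound 3 (1.52 log units; beyond the scatter) and an 8.9-fold higher number from compound 2 to compound 3 (0.95 log units; beyond the scatter). Compound 4 `Cn1ccnc1SCc1ccc(-c2noc(-c3ccc(C4=NCCN4)cc3)n2)cc1` carries (1-methyl-1H-imidazol-2-yl)sulfanyl in place of 1H-1,2,4-triazol-1-yl on a saturated chain carbon bound to an aromatic carbon. Among the compounds with values here, no measured pair shows this exact exchange; the two steps above only show that changes at the same position moved this assay by modest to large amounts, both away from the triazolylmethyl of compound 3. A modest move back is therefore expected, with the direction uncertain, as a 2.7-fold lower number from compound 3 to compound 4 (0.44 log units; beyond the scatter). Compound 4 is estimated at 9000 nM, within 2000 nM to 40000 nM.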

Compound 4, half-maximal inhibitory concentration: 12400 nM
Compound 4: the middle estimate sits 1.4-fold (0.14 log units) below what was measured; low and high end bracket the measured number.
By their numbers in this assay, from the lowest: compound 1; then compound 2; then compounds 4 and 3 (each within the scatter of the next).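

In this assay the exchange on this saturated chain carbon gives a 2.0-fold lower number from compound 3 to compound 4 (0.30 log units; within the scatter) and so does not separate the (1-methyl-1H-imidazol-2-yl)sulfanyl group from the 1H-1,2,4-triazol-1-yl group. Replacing the aromatic-carbon substituents of the other two compounds with ((1-methyl-1H-imidazol-2-yl)sulfanyl)methyl gives a 4.5-fold higher number from compound 2 to compound 4 (0.65 log units; beyond the scatter) and a 17-fold higher number from compound 1 to compound 4 (1.22 log units; beyond the scatter) and so keeps compound 4 with compound 3 at the weak end of the series. Nothing available here accounts for these steps.

Still open, going by these compounds, is whether a plain phenyl or a dimethylamino group on that saturated chain carbon would behave like these two groups, and whether a longer chain would move the number at all.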